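Hydroxycarbamoyl returned to the unsubstituted-phenyl triazole

This account rests on a few compounds, and the source may have more. Where it says the series, first, only, none or still open, it means among the compounds named here.

The series shares one core. Compound 1 is `O=C(NO)c1ccc(NCc2nc(-c3ccccc3)nn2-c2cccc(Cl)c2)cc1` and compound 2 is `Cc1cccc(-n2nc(-c3ccccc3)nc2CNc2ccc(C(=O)NO)cc2)c1`; they differ only by methyl in place of chloro on an aromatic carbon. Compound 3 is `CNC(=O)c1ccc(NCc2nc(-c3ccccc3)nn2-c2ccccc2)cc1`, which carries methylcarbamoyl where compound 1 and compound 2 carry hydroxycarbamoyl, and which bears a plain phenyl on the triazole nitrogen.

In an assay on Sf9 cells for inhibition of protein deacetylase HDAC6 (Homo sapiens), read by fluorescence, with a stated time of 40 min, tested at 100 nM (on this read-out higher numbers stand for more inhibition at the one concentration tested (going by the name of the read-out) and lower numbers for less inhibition), compound 1 gives 62.3% and compound 2 gives 66%; the step of a number 3.7 percentage points higher from compound 1 to compound 2 (within the scatter) lies within the scatter. In this assay compound 3 gives -3.6%, the lowest of the three numbers, beyond the scatter from both compound 1 and compound 2.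

Compound 4 is `O=C(NO)c1ccc(NCc2nc(-c3ccccc3)nn2-c2ccccc2)cc1`. The change from compound 3 to compound 4 is hydroxy in place of methyl on an amide-type nitrogen. Among the compounds with values here, no measured step covers this exchange directly. Two things bear on it: compound 1 and compound 2, both hydroxycarbamoyl, sit far above compound 3, and a number 3.7 percentage points higher from compound 1 to compound 2 (within the scatter) shows that the group on the aromatic carbon moves the number only within the scatter. Compound 4 is therefore expected to land near compound 1 and compound 2, giving an upward step a number 65.6 percentage points higher from compound 3 to compound 4 (beyond the scatter) well beyond the scatter. Compound 4 is estimated at 62%, with a range from 48% to 74%.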

Compound 4, a percentage reported as inhibition, at one concentration (the size of the read-out at that concentration, not a potency): 72.6%
For compound 4 the middle estimate is 10.6 percentage points below the measured one, within the range that was stated.
By their numbers in this assay, from the lowest: compound 3; then compounds 1, 2 and 4 (each within the scatter of the next, the first and the last beyond it).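

The exchange can now be read directly with the plain phenyl held constant: in this assay, hydroxy in place of methyl on the amide-type nitrogen, whose other neighbour is the carbonyl carbon, gives a number 76.2 percentage points higher from compound 3 to compound 4 (beyond the scatter), so the change from methylcarbamoyl to hydroxycarbamoyl alone accounts for this large step. The aromatic carbon now has a hydrogen reference point: hydrogen in place of methyl gives a number 6.6 percentage points higher from compound 2 to compound 4 (within the scatter), whereas hydrogen in place of chloro gives a number 10.3 percentage points higher from compound 1 to compound 4 (beyond the scatter), and both steps are small beside the one at the nitrogen. Nothing shown here explains the size of the nitrogen step or the modest difference between the chloro and hydrogen compounds.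

The compounds shown leave open how other groups on that nitrogen, such as methoxy or an amine, would read, and whether a carboxylic acid in place of the whole hydroxycarbamoyl group would behave like hydroxycarbamoyl or methylcarbamoyl. Also open, as far as these compounds go, is how methoxy or fluoro on the aromatic carbon would compare with hydrogen, methyl and chloro, and how these single-concentration readings relate to potency.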